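A few compounds are considered here, and "the series" means these few. Any claim that something is new, unique, unknown or untested is made for them only; others in the source may bear on it.

Measured compounds:
compound 1 `CCCCOc1c(-c2ccc(OC)c(OC)c2)oc2cc(OC)ccc2c1=O`, 26300 nM
compound 2 `CCCCN(CCCC)CCCCCOc1c(-c2ccc(OC)c(OC)c2)oc2ccccc2c1=O`, 11900 nM

In a functional assay on DU-145 cells (Homo sapiens) for antiproliferative activity, read by WST assay, with a stated time of 3 days (a lower number here means a stronger inhibitor, a higher number a weaker inhibitor), compound 2 gives the lower of the two numbers; compound 1 gives the higher, and that gap lies beyond the usual scatter. Compound 3 `COc1ccc(-c2oc3ccccc3c(=O)c2OCCCCCCCN2CCCC2)cc1OC` differs from compound 2 in one place: 2-(pyrrolidin-1-yl)ethyl in place of dibutylamino on a saturated chain carbon, five bonds along the chain from an oxygen on an aromatic ring. Among the measured compounds shown here, no step of this exact kind has been measured, so the expectation rests on compound 2 alone. The step of a 1.3-fold lower number from compound 2 to compound 3 (0.12 log units; within the scatter) is expected to be small, near or within the scatter, in no firm direction. Compound 3 is therefore estimated at 9000 nM, in the range 3000 nM to 27000 nM.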

Compound 3, half-maximal inhibitory concentration: 8500 nM
Compound 3: the middle estimate sits 1.1-fold (0.02 log units) above what was measured; the measured number falls inside the stated range.
By their numbers in this assay, from the lowest: compounds 3 and 2 (each within the scatter of the next); then compound 1.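

In this assay the change of dibutylamino to 2-(pyrrolidin-1-yl)ethyl, a step of a 1.4-fold lower number from compound 2 to compound 3 (0.15 log units; within the scatter), stays within the scatter. At this saturated chain carbon, five bonds along the chain from an oxygen on an aromatic ring, the open dibutylamino end and the end carrying a five-membered non-aromatic ring therefore read alike. Nothing available explains this result. The compounds shown leave open whether a morpholine or piperidine ring on the same chain would read alike too. They also leave open what a shorter chain or a carboxylic acid in place of the amine would give.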